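Chloro in Place of Hydrogen: Compound 2 to Compound 4

The source may hold more compounds than are shown below. What is called first, only, known or untested is meant among the compounds shown, and "the series" means these compounds.

Compound 2 `C=C1C[C@]23C[C@@]1(O)CC[C@H]2c1cc(Br)c(O)c(C)c1[C@@H]3Cn1cc(-c2ccccc2)nn1` carries bromo on an aromatic carbon of the shared core. In a functional assay on MCF7 cells (Homo sapiens) for cytotoxicity, read by MTT assay, with a stated time of 4 days (on this read-out higher numbers stand for weaker inhibition and lower numbers for stronger inhibition), compound 2 gives only a limit, > 20000 nM. Compound 1 `C=C1C[C@]23C[C@@]1(O)CC[C@H]2c1ccc(O)c(C)c1[C@@H]3Cn1cc(-c2ccccc2)nn1`, lacking that bromo, also sits at a limit in this assay, > 20000 nM. The step that the two limits leave unreadable from compound 1 to compound 2 is therefore unreadable; (the limit of > 20000 nM in this assay, at which 2 of the 3 values shown sit). Compound 3 `C=C1C(=O)[C@]23C[C@@]1(O)CC[C@H]2c1ccc(O)c(C)c1[C@@H]3Cn1cc(-c2ccc(Br)cc2)nn1` differs from compound 2 in more than one place, and in this assay compound 3 gives 270 nM. Compound 4 `C=C1C[C@]23C[C@@]1(O)CC[C@H]2c1cc(Br)c(O)c(C)c1[C@@H]3Cn1cc(-c2ccc(Cl)cc2)nn1` differs from compound 2 by chloro in place of hydrogen on an aromatic carbon. No measured step bears on this change, and the one step shown is itself unreadable, so neither direction nor size can be drawn from the data. Compound 4 is therefore expected to remain near the limit, with an estimated value of 20000 nM (range 5000 nM to 60000 nM), an expected step of a number no higher from compound 2 to compound 4 (the limit leaves the size open).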

Compound 4, half-maximal inhibitory concentration: 10200 nM
Estimate against measurement, compound 4: 2.0-fold (0.29 log units) above; the measured number falls inside the stated range.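

In this assay, chloro on the phenyl ring gives an at least 1.9-fold lower number from compound 2 to compound 4 (0.29 log units; that floor lies within the scatter), and of the compounds with bromo on the shared core, compound 4 alone gives a number rather than a limit. That floor lies within the usual scatter, so a real change is not established. The true size of the step stays open because compound 2 sits at a limit: the limit of > 20000 nM in this assay, at which 2 of the 4 values shown sit.

Going by these compounds, whether chloro at this position would act the same without the bromo on the shared core remains open. So does whether an amine or a carboxylic acid there would differ from chloro.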